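Replacing a Benzyloxycarbonyl Group on a Shared Core

The source may hold more compounds than are shown below. What is called first, only, known or untested is meant among the compounds shown, and "the series" means these compounds.

In a functional assay on the whole organism (Tail, strain ICR) with Mus musculus as the target, in the tail flick test, with a stated time of 120 min, at a dose of 25 umol/kg by the oral route (on this read-out lower numbers stand for a weaker effect and higher numbers for a stronger effect at the one dose given), compound 1 `O=C(CN(c1ncnc2c1ncn2C1CCCCO1)C1CC1)N[C@@H](CCC(=O)OCc1ccccc1)C(=O)OCc1ccccc1` gives 20.7%. Compound 2 `CC[C@H](C)[C@H](NC(=O)CN(c1nc(Cl)nc2[nH]cnc12)C1CC1)C(=O)O` gives 21.4% and compound 3 `CC(C)[C@H](NC(=O)CN(c1nc(Cl)nc2[nH]cnc12)C1CC1)C(=O)O` gives 17.1%. All three numbers lie within the usual scatter of one another, so compound 1 cannot be told apart from compound 2 or from compound 3. Among the measured compounds shown here, the one measured step among them, a number 4.3 percentage points lower from compound 2 to compound 3 (within the scatter), is small. Compound 4 `N=C(N)NCCC[C@H](NC(=O)CN(c1ncnc2c1ncn2C1CCCCO1)C1CC1)C(=O)OCc1ccccc1` differs from compound 1 by a group of 5 heavy atoms (2 carbon, 3 nitrogen; no ring) in place of a group of 10 heavy atoms (8 carbon, 2 oxygen; one six-membered aromatic ring of carbon only), on a saturated chain carbon, three bonds along the chain from an amide-type nitrogen and a carbonyl carbon. For the measured compounds named here, no measured pair shows this exchange; the only step at that place, hydrogen in place of methyl, stays within the scatter. The account therefore expects no step beyond the scatter, with a number 0.7 percentage points lower from compound 1 to compound 4 (within the scatter) as the estimated shift. Compound 4 is estimated at 20%, expected between 8% and 35%.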

Compound 4, a percentage reported as activity, at one dose (the size of the read-out at that dose, not a potency): 38.2%
The estimate for compound 4 lay 18.2 percentage points below the measured number; measured number outside the range, above it.
By their numbers in this assay, from the lowest: compounds 3, 1 and 2 (each within the scatter of the next); then compound 4.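

At this place, on a saturated chain carbon, three bonds along the chain from an amide-type nitrogen and a carbonyl carbon, exchanging benzyloxycarbonyl for the group of 5 heavy atoms (2 carbon, 3 nitrogen; no ring) gives (a number 17.5 percentage points higher from compound 1 to compound 4 (beyond the scatter)) in this assay. The place can therefore move this read-out, which the earlier hydrogen-for-methyl step (a number 4.3 percentage points lower from compound 2 to compound 3 (within the scatter)) did not show. Nothing measured here bears on what lies behind the rise.

As far as these compounds go, whether the step comes from losing benzyloxycarbonyl or from the entering group stays open. So does whether an amine at this place would give a similar number.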